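Replacing one chlorine with two on the pendant phenyl

The source may hold more compounds than are shown below. What is called first, only, known or untested is meant among the compounds shown, and "the series" means these compounds.

For the measured compounds named here, compound 1, `CC(=O)Nc1cccc(C2CCN(CCCn3c(-c4ccccc4Cl)nc4ccccc43)CC2)c1`, stands second highest of the three numbers measured so far: in an assay for displacement of a labelled ligand from melanin-concentrating hormone receptor 1 (Homo sapiens), read by fluorescence (a higher number here means a weaker inhibitor, a lower number a stronger inhibitor), compound 1 gives 10 nM. Compound 2, `CC(=O)Nc1cccc(C2CCN(CCCn3c(-c4cccc(Cl)c4)nc4ccccc43)CC2)c1`, gives 5 nM, and compound 3, `CC(=O)Nc1cccc(C2CCN(CCCn3c(-c4ccc(C(C)C)cc4)nc4ccccc43)CC2)c1`, gives 60 nM. The unmeasured compound 4 is `CC(=O)Nc1cccc(C2CCN(CCCn3c(-c4ccc(Cl)c(Cl)c4)nc4ccccc43)CC2)c1`; compared with compound 1 the change is 3,4-dichlorophenyl in place of 2-chlorophenyl on an aromatic carbon. Going by the values given here, two measured steps bear on this. The step of a 2.0-fold lower number from compound 1 to compound 2 (0.30 log units; within the scatter) shows that moving the single chlorine to the 3-position leaves the number within the scatter. The step of a 6.0-fold higher number from compound 1 to compound 3 (0.78 log units; beyond the scatter), and the larger 12-fold higher number from compound 2 to compound 3 (1.08 log units; beyond the scatter), show that a 4-isopropylphenyl group weakens binding. Compound 4 carries both a chlorine where compound 2 has one and a second chlorine where compound 3 carries its isopropyl, so a small shift toward a higher number is expected, though a chlorine is not an isopropyl and the two cases may not behave alike. Compound 4 is therefore estimated at 15 nM, between 4 nM and 50 nM, an expected step of a 1.5-fold higher number from compound 1 to compound 4 (0.18 log units; within the scatter).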

Compound 4, half-maximal inhibitory concentration: 24 nM
The estimate for compound 4 lay 1.6-fold (0.20 log units) below the measured number, within the range that was stated.
By their numbers in this assay, from the lowest: compounds 2 and 1 (each within the scatter of the next); then compound 4; then compound 3.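

At this position a second chlorine is not neutral: adding one to the 3-chlorophenyl group gives a 4.8-fold higher number from compound 2 to compound 4 (0.68 log units; beyond the scatter) in this assay even though moving a single chlorine had stayed within the scatter. The 3,4-dichlorophenyl group falls in the middle of the series, with a 2.4-fold higher number from compound 1 to compound 4 (0.38 log units; beyond the scatter) and a 2.5-fold lower number from compound 3 to compound 4 (0.40 log units; beyond the scatter) from the other side, so the two groups substituted at the 4-position, 3,4-dichlorophenyl and 4-isopropylphenyl, both give higher numbers than 2-chlorophenyl and 3-chlorophenyl. Nothing available explains why the second chlorine raises the number.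

The compounds shown leave open whether 4-chlorophenyl, with its single chlorine, would sit with compounds 1 and 2 or with compounds 3 and 4. They also leave open how an unsubstituted phenyl or a 4-methoxyphenyl group would compare.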